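The compounds below may be only part of what the source reports. "The series", "measured", "known", "first", "only" and "open" are said of these compounds alone.

Measured in a functional assay on PANC-1 cells (Homo sapiens) for inhibition, read by MTT assay, with a stated time of 24 h, tested at 10 uM; on this read-out lower numbers stand for less inhibition and higher numbers for more inhibition at the one concentration tested (going by the name of the read-out):
compound 1, `CC(C)=CCC1Cc2c(OCCCNC(=O)c3ccc([N+](=O)[O-])cc3)cc(=O)n(CCCO)c2CC1(C)C`: 49.9%
compound 2, `COc1ccc(OCCCOc2cc(=O)n(CCCO)c3c2CC(CC=C(C)C)C(C)(C)C3)cc1`: 47.7%
compound 3, `CC(C)=CCC1Cc2c(OCCCOc3ccc(Cl)cc3)cc(=O)n(CCCO)c2CC1(C)C`: 22.7%

Compound 3 stands lowest of these three numbers. Its nearest neighbour is compound 2, and the step of a number 25 percentage points lower from compound 2 to compound 3 (beyond the scatter) lies beyond the scatter; the step of a number 27.2 percentage points lower from compound 1 to compound 3 (beyond the scatter) is of about the same size. Between compound 1 and compound 2 the step of a number 2.2 percentage points lower from compound 1 to compound 2 (within the scatter) is within the scatter, so those two cannot be ordered against each other.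

Compound 4, `CC(C)=CCC1Cc2c(OC(=O)Nc3ccc(F)cc3F)cc(=O)n(CCCO)c2CC1(C)C`, is not yet measured. Relative to compound 3 the change is (2,4-difluorophenyl)carbamoyl in place of 3-(4-chlorophenoxy)propyl on an oxygen on an aromatic ring. Neither measured step matches this change: the steps that end at compound 3 exchange one aryl group for another at the end of the same chain, while here the whole chain leaves and a carbamoyl group enters on the oxygen on the aromatic ring. What the measured steps do show is that exchanging the group at the end of this side chain moves the number by a modest amount. Going by the values given here, compound 1, the one measured compound carrying a hydrogen-bond donor in its side chain, gives 49.9%, and compound 4 also carries one donor, so a number somewhat above compound 3 is expected, with wide uncertainty. The expected step of a number 12.3 percentage points higher from compound 3 to compound 4 (beyond the scatter) is thus a modest rise. Compound 4 is estimated at 35%, range 15% to 60%.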

Compound 4, a percentage reported as inhibition, at one concentration (the size of the read-out at that concentration, not a potency): 69.7%
Beside the measured number, compound 4's estimate is 34.7 percentage points below it, and the stated range ends below it.
By their numbers in this assay, from the lowest: compound 3; then compounds 2 and 1 (each within the scatter of the next); then compound 4.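

In this assay, going by these compounds alone, the step of a number 47 percentage points higher from compound 3 to compound 4 (beyond the scatter) is large, and it is the first one that removes the whole 3-(4-chlorophenoxy)propyl group from the oxygen on an aromatic ring instead of exchanging only the end of the side chain. The earlier steps shown here to compound 3 were modest and the step between compound 1 and compound 2 lay within the scatter, so this position can carry more than the propyl ether and amide chains seen so far, and compound 4 at 69.7% prints above compound 1 at 49.9%. The group leaving and the group entering have the same heavy-atom count and one aromatic ring each, so neither count separates compound 3 from compound 4, while the carbamoyl group, the hydrogen-bond donor, the fluorines and the loss of the chain all change in this single step.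

Open, going by these compounds, is which of these parts carries the rise, a question that an unsubstituted phenyl on the carbamoyl group, or a methyl in place of the amide hydrogen, would address. No measurement shown here bears on the reason for this rise.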